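A Hydrazide Chain Replaces an Ester on the Ring Nitrogen

This account rests on a few compounds, and the source may have more. Where it says the series, first, only, none or still open, it means among the compounds named here.

Compound 1 `COC(=O)C(C)N1C(=O)c2ccccc2NC1c1ccco1` holds the lowest of the three numbers measured in an assay on mitochondria for inhibition of Amine oxidase [flavin-containing] A (Bos taurus), read by fluorescence, with a stated time of 60 min; on this read-out higher numbers stand for weaker inhibition and lower numbers for stronger inhibition; compound 1 gives 8.2 nM. Compound 3 `NNC(=O)CCN1C(=O)c2ccccc2NC1c1ccccc1` stands nearest: in this assay compound 3 gives 16 nM, a gap that lies within the usual scatter. Compound 2 `COC(=O)CCN1C(=O)c2ccccc2NC1c1ccc(Cl)cc1` stands furthest: in this assay compound 2 gives 98 nM, a gap beyond the scatter. Compound 4 `NNC(=O)CCCN1C(=O)c2ccccc2NC1c1ccco1` has not yet been measured. It differs from compound 1 in one place: 3-(aminocarbamoyl)propyl in place of 1-(methoxycarbonyl)ethyl on an amide-type nitrogen in a ring. Going by the values given here, no pair of measured compounds differs in only this place, so no measured step shows how such a change shifts the numbers in this assay. Compound 3, which also carries an aminocarbamoyl chain on a ring nitrogen, gives 16 nM, and on that ground no large shift is expected. For compound 4 a step of a 1.8-fold higher number from compound 1 to compound 4 (0.26 log units; within the scatter) is expected, none beyond the scatter. Compound 4 is estimated at 15 nM, with a range from 4 nM to 60 nM.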

Compound 4, half-maximal inhibitory concentration: 36 nM
Compound 4: middle estimate off by 2.4-fold (0.38 log units), on the low side; measured number inside the range.
By their numbers in this assay, from the lowest: compounds 1 and 3 (each within the scatter of the next); then compound 4; then compound 2.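

In this assay, going by these compounds alone, placing 3-(aminocarbamoyl)propyl in place of 1-(methoxycarbonyl)ethyl on the amide-type nitrogen in the ring gives a 4.4-fold higher number from compound 1 to compound 4 (0.64 log units; beyond the scatter), the first measured step at this position. The furan-2-yl group and the rest of the core of compound 1 are unchanged in compound 4. The chain that leaves has 0 hydrogen-bond donors, and the chain that enters has 2. No measurement available here ties the step to any particular feature of either chain.

The exchange alters the end group, the chain length and the branching together, so the compounds shown leave open which of these accounts for the step. Also open, as far as these compounds go, is where a 3-(methoxycarbonyl)propyl chain, or a propyl chain ending in a carboxylic acid or an amine, would fall on this read-out.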